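A few compounds are considered here, and "the series" means these few. Any claim that something is new, unique, unknown or untested is made for them only; others in the source may bear on it.

Values in a functional assay on MDA-MB-231 cells (Homo sapiens) for inhibition, read by CellTiter-Glo, with a stated time of 72 h (a lower number here means that less compound is tolerated, a higher number that more compound is tolerated), so far:
- compound 1 `CC1=C(CC(=O)NCCN(C)C)c2cc(F)ccc2/C1=C\c1ccc(S(C)(=O)=O)cc1` gives 37500 nM
- compound 2 `COC(=O)[C@H](C)NC(=O)CC1=C(C)/C(=C/c2ccc(SC)cc2)c2ccc(F)cc21` gives 38900 nM
- compound 3 `CC1=C(CC(=O)N(C)CCN(C)C(=O)[C@@H](N)C(C)C)c2cc(F)ccc2/C1=C\c1ccc([S+](C)[O-])cc1` gives > 50000 nM, a limit of the assay and not a number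

Compound 3 therefore has no exact position in the series, only the limit shown in the limit of > 50000 nM in this assay, at which 1 of the 3 values shown sits. Compound 4 `CC1=C(CC(=O)N(C)CCN(C)S(=O)(=O)c2ccccc2)c2cc(F)ccc2/C1=C\c1ccc([S+](C)[O-])cc1` carries phenylsulfonyl in place of (1-amino-2-methylpropyl)carbonyl on an amine nitrogen, with the difference counted as phenylsulfonyl in place of (1-amino-2-methylpropyl)carbonyl on an amine nitrogen. For the measured compounds named here, no measured pair isolates this change. Compound 1 gives 37500 nM and compound 2 gives 38900 nM, so the expectation stays in this high range. Only a small step towards lower values in this assay is expected, estimated as an at least 1.3-fold lower number from compound 3 to compound 4 (0.11 log units; that floor lies within the scatter). For compound 4 the estimated value is 38000 nM, with an expected range of 15000 nM to 70000 nM.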

Compound 4, half-maximal cytotoxic concentration: 12200 nM
Estimate against measurement, compound 4: 3.1-fold (0.49 log units) above; measured number outside the range, below it.
By their numbers in this assay, from the lowest: compound 4; then compounds 1 and 2 (each within the scatter of the next). At a limit, above all of these: compound 3.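

In this assay, for the compounds shown here, phenylsulfonyl in place of (1-amino-2-methylpropyl)carbonyl on this amine nitrogen gives an at least 4.0-fold lower number from compound 3 to compound 4 (0.61 log units; beyond the scatter), the first step read at this position; the earlier compounds held no pair that isolated it. The step is only a floor, since compound 3 stands at a limit of the assay and not at a number: the limit of > 50000 nM in this assay, at which 1 of the 4 values shown sits.

The compounds shown do not separate the aromatic ring of phenylsulfonyl from its sulfonyl link. A methylsulfonyl or benzoyl group on the same nitrogen would bear on that question.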